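This account rests on a few compounds, and the source may have more. Where it says the series, first, only, none or still open, it means among the compounds named here.

Of the compounds shown here, three in this set have been measured in a functional assay on HCC78 cells (Homo sapiens) for antiproliferative activity, read by MTT assay, with a stated time of 48 h; a higher number here means a weaker inhibitor, a lower number a stronger inhibitor. Compound 1 `Cc1ccc(CNC(=O)c2cccc(C(C)Oc3cccnc3Nc3ncc(C)s3)c2)cc1` gives 14800 nM, compound 2 `Cc1ccc(CNC(=O)c2cccc(C(C)Oc3ccnc(Nc4cn(C)nc4C)c3)c2)cc1` gives 17500 nM, and compound 3 `CC(Oc1ccnc(NN2CCN(C)CC2)c1)c1cccc(C(=O)NCc2ccc(Cl)c(C(F)(F)F)c2)c1` gives 23500 nM. Compound 2 stands second highest of the three numbers; its nearest neighbour is compound 1, whose number is within the scatter of it, and even compound 3, the furthest, is within the scatter as well. All three numbers therefore sit at one level, with no order among them that the data can support.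

Compound 4 `Cc1ccc(CNC(=O)c2cccc(C(C)Oc3ccnc(Nc4cnn(CC(C)(C)O)c4)c3)c2)cc1` keeps the core of compound 2 and changes only the group on the amino nitrogen: 1-(2-hydroxy-2-methylpropyl)-1H-pyrazol-4-yl in place of 1,3-dimethyl-1H-pyrazol-4-yl on a nitrogen on an aromatic ring. For the measured compounds named here, no pair of measured compounds differs in one place, so no measured step guides this change. The three numbers of compounds 1, 2 and 3 show that quite different groups at this end leave the number within the scatter, and the same is expected here: the step from compound 2 to compound 4 is expected to be a 1.0-fold lower number from compound 2 to compound 4 (0.01 log units; within the scatter), none beyond the scatter. Compound 4 is estimated to give 17000 nM in this assay, with a range from 6000 nM to 50000 nM.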

Compound 4, half-maximal inhibitory concentration: 49700 nM
The estimate for compound 4 lay 2.9-fold (0.47 log units) below the measured number, and the stated range covers the measured number.
By their numbers in this assay, from the lowest: compounds 1, 2 and 3 (each within the scatter of the next); then compound 4.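

For the compounds shown here, the group on the amino nitrogen is not without effect in this assay: the one comparison between compounds that differ in a single place gives a 2.8-fold higher number from compound 2 to compound 4 (0.45 log units; beyond the scatter). Unlike the earlier numbers, which sat at one level, this shows that a change at this position can move the number beyond the scatter, here with the five-membered aromatic ring kept and the 2-hydroxy-2-methylpropyl group entering, although the step is modest and rests on a single pair. Nothing shown here explains this step.

Going by these compounds, it remains open whether the hydroxyl or the carbon chain that carries it accounts for the step, which a 2-methylpropyl chain on the same pyrazole would separate. On these data alone, whether an amine or a carboxylic acid in place of the hydroxyl would move the number in the same direction also remains open.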